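The source may report more compounds than this note shows. Statements on the series, on what has been measured and on what is new or still open speak of the compounds shown alone.

Values in an ADME assay on Vero cells (Chlorocebus sabaeus) for cytotoxicity, read by MTT assay, with a stated time of 72 h; a lower number here means that less compound is tolerated, a higher number that more compound is tolerated:
Compound 1 `CC/C(=C\c1ccc(Cl)cc1)C(=O)/C=C/c1ccc([N+](=O)[O-])cc1` gives 36000 nM
Compound 2 `COc1ccc(/C=C(\C)C(=O)/C=C/c2ccccc2Br)cc1` gives 71000 nM
Compound 3 `COc1ccc(/C=C(\C)C(=O)/C=C/c2ccc(/C=C/C(=O)/C(C)=C/c3ccc(OC)cc3)cc2)cc1` gives 460000 nM

Of these three, compound 1 and compound 2 lie within the usual scatter of each other, so they share the low end of the range. Compound 3 stands clearly higher than compound 1, which means that much more of it is tolerated by the cells.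

Compound 4 `CC/C(=C\c1ccc(Cl)cc1)C(=O)/C=C/c1ccc(Br)cc1` has yet to be tested. It keeps the core of compound 1 and changes one group: bromo in place of nitro on an aromatic carbon. In words, bromo takes the place of nitro on an aromatic carbon.

For the measured compounds named here, no pair of measured compounds differs in just one place, so the size of this step has no direct precedent. Compound 2 also carries a bromo group and gives 71000 nM, close to the value of compound 1. A small upward shift is therefore expected, with nothing beyond the scatter: the estimate is a 1.3-fold higher number from compound 1 to compound 4 (0.10 log units; within the scatter). For compound 4 the expected value is 45000 nM, with an estimated range of 18000 nM to 110000 nM.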

Compound 4, half-maximal cytotoxic concentration: 29400 nM
For compound 4 the middle estimate is 1.5-fold (0.18 log units) above the measured one; measured number inside the range.
By their numbers in this assay, from the lowest: compounds 4, 1 and 2 (each within the scatter of the next, the first and the last beyond it); then compound 3.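

In this assay, putting bromo in place of nitro on an aromatic carbon para to a large group gives a 1.2-fold lower number from compound 1 to compound 4 (0.09 log units; within the scatter), so the two groups cannot be told apart at this position in this assay. The step removes the larger nitro group and its hydrogen-bond acceptors, yet the number stays within the scatter. No measurement here explains why the number holds steady across this change.

From the compounds shown here alone, it remains open whether a different kind of group at this position, such as an amine or a carboxylic acid, would move the number beyond the scatter. The compounds shown also leave open how the number would respond if the chloro group of compound 4 gave way to one of these groups.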